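Compound 1 to compound 3: an aryl exchange

A few compounds are considered here, and "the series" means these few. Any claim that something is new, unique, unknown or untested is made for them only; others in the source may bear on it.

For the measured compounds named here, in a functional assay on HeLa cells (Homo sapiens) for antiproliferative activity, read by spectrophotometry, with a stated time of 2 days (on this read-out lower numbers stand for stronger inhibition of growth and higher numbers for weaker inhibition of growth), compound 1 (`COc1ccc(Nc2ncc(C(F)(F)F)c(N3Cc4cccc(N(C)S(C)(=O)=O)c4C3)n2)cc1C(F)(F)F`) gives 14000 nM and stands highest of the two numbers so far. Compound 2 (`CC(=O)N1CCN(c2ccc(Nc3ncc(C(F)(F)F)c(N4Cc5cccc(N(C)S(C)(=O)=O)c5C4)n3)cc2)CC1`) gives 730 nM and lies lower, beyond the scatter. Compound 3 (`Cc1ccc(Nc2ncc(C(F)(F)F)c(N3Cc4cccc(N(C)S(C)(=O)=O)c4C3)n2)cc1C`) carries 3,4-dimethylphenyl in place of 4-methoxy-3-(trifluoromethyl)phenyl on a nitrogen on an aromatic ring. Going by the values given here, no measured pair isolates this change, so the expectation is loose. Among the compounds with values here, a lower number is expected mainly because compound 1 gives 14000 nM at the top of the numbers so far. Expected in this assay is a 4.7-fold lower number from compound 1 to compound 3 (0.67 log units; beyond the scatter) and thus a moderate move to a lower number. The value of compound 3 is estimated at 3000 nM (range 800 nM to 11000 nM).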

Compound 3, concentration for 50% growth inhibition: > 30000 nM
Compound 3 gave a limit, no number; the forecaster's own chance of this, stated with the estimate: 5%; at least 10-fold (1.00 log units) between middle value and limit.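

In this assay, for the compounds shown here, 3,4-dimethylphenyl in place of 4-methoxy-3-(trifluoromethyl)phenyl on a nitrogen on an aromatic ring gives an at least 2.1-fold higher number from compound 1 to compound 3 (0.33 log units; beyond the scatter), the first single-place step and one towards weaker inhibition of growth. Compound 3 gives > 30000 nM, which is a limit of the assay and not a number. The size of the step therefore has only a lower bound because of where compound 3 sits: the limit of > 30000 nM in this assay, at which 1 of the 3 values shown sits.

Going by these compounds, how far the true value of compound 3 lies past that limit remains open. Also open, on these data alone, is how a primary amine or a carboxylic acid on this phenyl ring would read in this assay.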